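The compounds below may be only part of what the source reports. "The series", "measured", "known", "first", "only" and "open" are said of these compounds alone.

Measured compounds:
compound 1, `O=[N+]([O-])c1ccccc1CSc1nnc(-c2ccc3c(c2)OCCO3)n1-c1ccccc1`: 8300 nM
compound 2, `O=[N+]([O-])c1ccc(CSc2nnc(-c3ccc4c(c3)OCCO4)n2-c2ccccc2)cc1`: 13800 nM

Within the data shown here, in a functional assay on SW 1116 cells (Homo sapiens) for antiproliferative activity, read by MTT assay, with a stated time of 24 h (on this read-out lower numbers stand for stronger inhibition and higher numbers for weaker inhibition), compound 2 gives 13800 nM, the higher of the two numbers measured so far; its only neighbour is compound 1, and the step of a 1.7-fold higher number from compound 1 to compound 2 (0.22 log units; within the scatter) stays within the scatter, so the two compounds cannot be told apart on this assay. Compound 3, `Cc1ccccc1CSc1nnc(-c2ccc3c(c2)OCCO3)n1-c1ccccc1`, is not yet measured; it differs from compound 2 in one place: 2-methylphenyl in place of 4-nitrophenyl on a saturated chain carbon bound to a sulfur. Among the measured compounds shown here, the single measured step, from compound 1 to compound 2, concerns only where the same group sits on the ring and says nothing about exchanging it for 2-methylphenyl, so no measured step bears directly on this change. For the measured compounds named here, with only that step within the scatter to go on, compound 3 is expected to give a number close to compound 2, a 1.2-fold lower number from compound 2 to compound 3 (0.06 log units; within the scatter), with no step beyond the scatter in either direction. Compound 3 is estimated at 12000 nM, within 4000 nM to 40000 nM.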

Compound 3, half-maximal inhibitory concentration: 12700 nM
The estimate for compound 3 lay 1.1-fold (0.02 log units) below the measured number; the range from low to high includes it.
By their numbers in this assay, from the lowest: compounds 1, 3 and 2 (each within the scatter of the next).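

In this assay, among these compounds, there is a 1.1-fold lower number from compound 2 to compound 3 (0.04 log units; within the scatter) when 4-nitrophenyl gives way to 2-methylphenyl, so this is the first sign that the nitro group can be replaced, and not just moved around the ring, without a change that can be told apart. The closest comparison, methyl in place of nitro on an aromatic carbon, gives a 1.5-fold higher number from compound 1 to compound 3 (0.18 log units; within the scatter) and shows that a group of carbon only, with no hydrogen-bond acceptors, fits these three compounds equally well. No separate measurement here helps to explain why the numbers stay so close.

A plain benzyl group, with neither methyl nor nitro, would show whether either group matters at all. As far as these compounds go, it also remains open whether an amine, a carboxylic acid or a longer chain in this place would shift the number beyond the scatter.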